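Methyl to trifluoromethyl on the outer phenyl ring

This account rests on a few compounds, and the source may have more. Where it says the series, first, only, none or still open, it means among the compounds named here.

Among the compounds with values here, in a functional assay on SF-295 cells (Homo sapiens) for inhibition, read by sulforhodamine B assay, with a stated time of 48 h, tested at 10 uM (a lower number here means a stronger effect, a higher number a weaker effect of the compound at the concentration tested), compound 2 `COc1cc2cc(Oc3ccc(NC(=O)Nc4ccc(C)cc4)cc3)c(C)nc2cc1OC` gives 107%, the higher of the two numbers known. Compound 1 `COc1cc2cc(Oc3ccc(NC(=O)Nc4ccccc4)cc3)c(C)nc2cc1OC` gives 54.1% in this assay. Within the data shown here, the single measured step, a number 52.9 percentage points higher from compound 1 to compound 2 (beyond the scatter), concerns a different change and so offers only indirect guidance. Compound 3 `COc1cc2cc(Oc3ccc(NC(=O)Nc4ccc(C(F)(F)F)cc4)cc3)c(C)nc2cc1OC` differs from compound 2 by trifluoromethyl in place of methyl on an aromatic carbon. Among the measured compounds shown here, no measured step bears directly on this change, so a move of any size in either direction remains possible. The step expected in this assay is a number 22 percentage points lower from compound 2 to compound 3 (beyond the scatter). For compound 3 the estimate is 85%, with a range from 50% to 115%.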

Compound 3, a percentage reported as activity, at one concentration (the size of the read-out at that concentration, not a potency): 56%
Compound 3: the middle estimate sits 29 percentage points above what was measured; measured number inside the range.
By their numbers in this assay, from the lowest: compounds 1 and 3 (each within the scatter of the next); then compound 2.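

this assay shows a number 51 percentage points lower from compound 2 to compound 3 (beyond the scatter) and so makes clear that the weaker effect seen with methyl does not extend to every group placed here. Trifluoromethyl in place of hydrogen gives a number 1.9 percentage points higher from compound 1 to compound 3 (within the scatter) and so leaves compound 3 indistinguishable from compound 1. No measured evidence accounts for the difference between methyl and trifluoromethyl. From the compounds shown here alone, whether a chlorine atom, a methoxy group or an amine at this carbon would behave like methyl or like trifluoromethyl remains open.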